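From 4-Hydroxyphenyl to 3-Methoxyphenyl on the Amide Nitrogen

The source may hold more compounds than are shown below. What is called first, only, known or untested is meant among the compounds shown, and "the series" means these compounds.

Compound 1, `CN(C)C(=O)c1cc2cnc(Nc3ccc(NC(=O)C4(C(=O)Nc5ccc(Br)cc5)CC4)cc3)nc2n1C1CCCC1`: 21.1%
Compound 2, `CN(C)C(=O)c1cc2cnc(Nc3ccc(NC(=O)C4(C(=O)Nc5cccc(Cl)c5)CC4)cc3)nc2n1C1CCCC1`: 39.3%
Compound 3, `CN(C)C(=O)c1cc2cnc(Nc3ccc(NC(=O)C4(C(=O)Nc5ccc(O)cc5)CC4)cc3)nc2n1C1CCCC1`: 91.5%

The three compounds share one core and differ only in the aryl group on the amide-type nitrogen. They were compared in a functional assay on T47D cells (Homo sapiens) for inhibition, read by CCK-8 assay, with a stated time of 72 h, tested at 1 uM; on this read-out higher numbers stand for more inhibition of growth at the one concentration tested and lower numbers for less inhibition of growth. Compound 3 stands highest of the three numbers shown, and both gaps to it lie beyond the scatter: the nearer one is a number 52.2 percentage points higher from compound 2 to compound 3 (beyond the scatter), the wider one is a number 70.4 percentage points higher from compound 1 to compound 3 (beyond the scatter). The smaller step, a number 18.2 percentage points higher from compound 1 to compound 2 (beyond the scatter), is modest.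

Compound 4, `COc1cccc(NC(=O)C2(C(=O)Nc3ccc(Nc4ncc5cc(C(=O)N(C)C)n(C6CCCC6)c5n4)cc3)CC2)c1`, differs from compound 3 in one place: 3-methoxyphenyl in place of 4-hydroxyphenyl on an amide-type nitrogen.

Going by the values given here, two measured steps bear on this change, since both lead into compound 3 and both bring the hydroxy group in; here that group leaves again. Compound 1 and compound 2, which lack it, sit far lower than compound 3, so a large downward step in this assay is expected for compound 4. Because a number 52.2 percentage points higher from compound 2 to compound 3 (beyond the scatter) was large, compound 4 is estimated to fall back toward the level of compound 2, with a number 46.5 percentage points lower from compound 3 to compound 4 (beyond the scatter). Compound 4 is therefore expected to give about 45%, in a range from 20% to 70%.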

Compound 4, percent growth inhibition at one concentration: 56.3%
The estimate for compound 4 lay 11.3 percentage points below the measured number, within the range that was stated.
By their numbers in this assay, from the lowest: compound 1; then compound 2; then compound 4; then compound 3.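

In this assay, 3-methoxyphenyl on the amide-type nitrogen gives up a large part of what 4-hydroxyphenyl delivers, with a number 35.2 percentage points lower from compound 3 to compound 4 (beyond the scatter) as the step, yet the loss of the hydrogen-bond donor does not bring the number back to the level of the halogen-bearing aryl groups. Methoxy in place of chloro on an aromatic carbon gives a number 17 percentage points higher from compound 2 to compound 4 (beyond the scatter) and 3-methoxyphenyl in place of 4-bromophenyl gives a number 35.2 percentage points higher from compound 1 to compound 4 (beyond the scatter) so that, among these four compounds, the two aryl groups carrying an oxygen stand above the two carrying a halogen, with no compound going against this order. No measurement offered alongside these numbers accounts for any of these steps.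

The step to compound 4 alters the substituent and its place on the ring together, so the compounds shown cannot say how much of it belongs to the capped oxygen and how much to the shifted position. 3-Hydroxyphenyl and 4-methoxyphenyl would separate those two changes, and 4-aminophenyl would show whether a nitrogen-bearing group can stand in for the hydroxy group.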